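The compounds below may be only part of what the source reports. "The series", "measured", "known", "first", "only" and "open" are said of these compounds alone.

Compound 2 `O=C(Nc1cc2c(Nc3ccc(F)c(Cl)c3)ncnc2cc1O[C@H]1CCOC1)N1CCC(F)CC1` gives 3040 nM in a functional assay on A-431 cells (Homo sapiens) for antiproliferative activity, read by sulforhodamine B assay, with a stated time of 72 h (on this read-out higher numbers stand for weaker inhibition and lower numbers for stronger inhibition), and the step of a 1.6-fold higher number from compound 1 to compound 2 (0.20 log units; within the scatter) shows that it and compound 1 `O=C(Nc1cc2c(Nc3ccc(F)c(Cl)c3)ncnc2cc1O[C@H]1CCOC1)N1CC(O)C1` lie within the scatter of each other, compound 1 giving 1930 nM. Compound 3 `O=C(Nc1cc2c(Nc3ccc(F)c(Cl)c3)ncnc2cc1O[C@H]1CCOC1)N1CCC(CCO)CC1` carries 2-hydroxyethyl in place of fluoro on a saturated ring carbon. For the measured compounds named here, the only measured step that bears on this, which also altered the group on the carbonyl carbon, is a 1.6-fold higher number from compound 1 to compound 2 (0.20 log units; within the scatter); it stayed within the scatter, and a hydroxyl-bearing group on that carbonyl was already tolerated in compound 1. Compound 3 is therefore expected to show a 1.2-fold lower number from compound 2 to compound 3 (0.08 log units; within the scatter), no step beyond the scatter. The estimate for compound 3 is 2500 nM, between 1200 nM and 5500 nM.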

Compound 3, half-maximal inhibitory concentration: 759 nM
Compound 3: middle estimate off by 3.3-fold (0.52 log units), on the high side, and the stated range ends above it.
By their numbers in this assay, from the lowest: compound 3; then compounds 1 and 2 (each within the scatter of the next).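

In this assay, for the compounds shown here, 2-hydroxyethyl in place of fluoro on this saturated ring carbon gives the first single change here to pass beyond the scatter (a 4.0-fold lower number from compound 2 to compound 3 (0.60 log units; beyond the scatter)). The whole 4-(2-hydroxyethyl)piperidin-1-yl group also separates from 3-hydroxyazetidin-1-yl (a 2.5-fold lower number from compound 1 to compound 3 (0.41 log units; beyond the scatter)), so a hydroxyl on the group at the carbonyl does not alone set the number. No evidence is available to account for these shifts. Going by these compounds, it remains open whether the hydroxyl or the chain matters, and how a plain ethyl, a 2-methoxyethyl, a 3-hydroxypropyl or a 2-aminoethyl group would read at this ring carbon.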